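Swapping one pyrazole-bearing group for another in a para-phenoxy series

A few compounds are considered here, and "the series" means these few. Any claim that something is new, unique, unknown or untested is made for them only; others in the source may bear on it.

Among the compounds with values here, compound 2 `CCCC(Oc1ccc(-n2cc3c(n2)CCCC3)cc1)c1ccc(C(=O)NCCC(=O)O)cc1` is the more lipophilic of the two compounds measured so far in a physicochemical assay for lipophilicity, using the shake flask method, at pH 7.4; a lower number here means a more polar compound, a higher number a more lipophilic compound: compound 2 gives 2.7, while compound 1 `O=C(O)CCNC(=O)c1ccc(C(Oc2ccc(-n3cc(C(F)(F)F)cn3)cc2)C2CC2)cc1` gives 1.7, a gap that lies beyond the usual scatter. Compound 3 `CCCC(Oc1ccc(-n2cc(C(F)(F)F)cn2)cc1)c1ccc(C(=O)NCCC(=O)O)cc1` has not yet been measured. It differs from compound 2 in one place: a group of 9 heavy atoms (4 carbon, 2 nitrogen, 3 fluorine; one five-membered aromatic ring with 2 hetero atoms) in place of a group of 9 heavy atoms (7 carbon, 2 nitrogen; one five-membered aromatic ring with 2 hetero atoms, one six-membered non-aromatic ring of carbon only), on an aromatic carbon, the position being para to a large group on that ring. Compound 3 also shares its 4-(trifluoromethyl)-1H-pyrazol-1-yl group with compound 1, though the two differ elsewhere, so the value of compound 1 serves only as a loose anchor. Within the data shown here, no measured pair in this set shows this exact change, so the step is a guess. For compound 3 a modest downward step is expected in this assay, of about a number 0.40 log units lower from compound 2 to compound 3 (beyond the scatter), close to the edge of the scatter. Compound 3 is estimated at 2.3, with a likely range from 1.8 to 2.8.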

Compound 3, distribution coefficient: 2.4
Compound 3: middle estimate off by 0.10 log units, on the low side, and the stated range covers the measured number.
By their numbers in this assay, from the lowest: compound 1; then compounds 3 and 2 (each within the scatter of the next).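

In this assay, the step for placing 4-(trifluoromethyl)-1H-pyrazol-1-yl on the aromatic carbon, in place of the group holding a six-membered carbon ring, is a number 0.30 log units lower from compound 2 to compound 3 (within the scatter), so these two quite different groups cannot be told apart at this position. Within the data shown here, with that pyrazole group shared, propyl in place of cyclopropyl on the saturated chain carbon gives a number 0.70 log units higher from compound 1 to compound 3 (beyond the scatter), the only single-place change here that clears the scatter. Nothing at hand explains either step.

Still open, as far as these compounds go, is whether a nitrile in place of trifluoromethyl on the pyrazole, or a butyl chain in place of propyl, would shift the number. Also open, from the compounds shown here alone, is whether the swap of the two pyrazole-bearing groups gives a similar step when cyclopropyl sits on the chain carbon.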